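The source may report more compounds than this note shows. Statements on the series, on what has been measured and on what is new or still open speak of the compounds shown alone.

Compound 3 `CCCc1nc(-c2ccccc2)c(CNCCCN2CCN(c3ccccc3Cl)CC2)o1` stands highest of the three measured compounds in an assay on HEK293 cells for inhibition of Voltage-dependent T-type calcium channel subunit alpha-1G (Homo sapiens), read by fluorescence, tested at 10 uM (on this read-out higher numbers stand for more inhibition at the one concentration tested (going by the name of the read-out) and lower numbers for less inhibition), where compound 3 gives 64.7%. Compound 1 `CCCc1nc(-c2ccccc2)c(CNCCCN2CCN(c3cccc(OC)c3)CC2)o1` gives 36.4%, and compound 2 `CCCc1nc(-c2ccccc2)c(CNCCCN2CCN(c3ccc(OC)cc3)CC2)o1` gives 42.1%. The rises a number 28.3 percentage points higher from compound 1 to compound 3 (beyond the scatter) and a number 22.6 percentage points higher from compound 2 to compound 3 (beyond the scatter) are modest and beyond the scatter, while a number 5.7 percentage points higher from compound 1 to compound 2 (within the scatter) lies within it. Compound 4 `CCCc1nc(-c2ccccc2)c(CNCCCN2CCN(c3ccccc3C(F)(F)F)CC2)o1` differs from compound 3 by trifluoromethyl in place of chloro on an aromatic carbon. Among the compounds with values here, no measured step exchanges one group for another at the same place on the aryl ring; the two rises into compound 3 show only that the 2-chlorophenyl arm lifts the read-out, so they bear on the new step only indirectly. Compound 4 is therefore expected near 65%, between 45% and 82%, an estimated step of a number 0.3 percentage points higher from compound 3 to compound 4 (within the scatter) within the scatter.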

Compound 4, a percentage reported as inhibition, at one concentration (the size of the read-out at that concentration, not a potency): 45%
Beside the measured number, compound 4's estimate is 20 percentage points above it, within the range that was stated.
By their numbers in this assay, from the lowest: compounds 1, 2 and 4 (each within the scatter of the next); then compound 3.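

In this assay the change at this place reads as a number 19.7 percentage points lower from compound 3 to compound 4 (beyond the scatter) and takes away the lift that the 2-chlorophenyl arm gave. Compound 4 thus lines up with the two methoxyphenyl compounds, as a number 2.9 percentage points higher from compound 2 to compound 4 (within the scatter) and a number 8.6 percentage points higher from compound 1 to compound 4 (within the scatter) show. Of the two groups compared at this place, only chloro goes with the higher read-out, and no evidence at hand accounts for the drop. As far as these compounds go, whether fluoro, bromo or methyl at the same place would hold the read-out of compound 3 stays open.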